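The compounds below may be only part of what the source reports. "The series", "measured", "known", "first", "only" and "open" are said of these compounds alone.

Measured compounds:
- compound 1, `Cc1cccc(C)c1-c1cccc(COc2ccc(S(=O)(=O)CC(=O)O)cc2)c1`, which in a functional assay on CHO cells for agonist activity at Free fatty acid receptor 1 (Homo sapiens), read by FLIPR and calcium flux (on this read-out higher numbers stand for an effect only at larger amounts of compound and lower numbers for an effect already at smaller amounts), gives 66.1 nM
- compound 2, `COc1ccccc1-c1cccc(COc2ccc(S(=O)(=O)CC(=O)O)cc2)c1`, which in this assay gives 195 nM

Of these two numbers, compound 2 carries the higher one. Within the data shown here, the only step between them runs from compound 1 to compound 2, where a 3.0-fold higher number from compound 1 to compound 2 (0.47 log units; beyond the scatter), and that step lies beyond the scatter, so compound 2 is the less potent of the pair in this assay.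

Compound 3, `Cc1ccc(-c2cccc(COc3ccc(S(=O)(=O)CC(=O)O)cc3)c2)c(Cl)c1`, has not yet been measured. Relative to compound 2, the change is 2-chloro-4-methylphenyl in place of 2-methoxyphenyl on an aromatic carbon. The group that enters carries no hydrogen-bond acceptor and sits on the same aromatic carbon, which in this respect brings compound 3 closer to compound 1 than to compound 2. The step from compound 1 to compound 2 is the one that bears on this change: replacing a methoxyphenyl bearer with a dimethyl one was worth a 3.0-fold higher number from compound 1 to compound 2 (0.47 log units; beyond the scatter). A partial reversal of that direction is therefore expected for compound 3 in this assay, with an estimated step of a 2.2-fold lower number from compound 2 to compound 3 (0.34 log units; beyond the scatter). For compound 3 the estimated value in this assay is 90 nM, with a range from 35 nM to 250 nM.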

Compound 3, half-maximal effective concentration: 36.3 nM
Estimate against measurement, compound 3: 2.5-fold (0.39 log units) above; the range from low to high includes it.
By their numbers in this assay, from the lowest: compounds 3 and 1 (each within the scatter of the next); then compound 2.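

In this assay, among these compounds, replacing 2-methoxyphenyl with 2-chloro-4-methylphenyl gives a 5.4-fold lower number from compound 2 to compound 3 (0.73 log units; beyond the scatter), so a second group at this position, meta to a large group, now stands apart from 2-methoxyphenyl beyond the scatter, where the earlier compounds offered only 2,6-dimethylphenyl for that comparison. The two groups without a hydrogen-bond acceptor cannot be told apart here, with a 1.8-fold lower number from compound 1 to compound 3 (0.26 log units; within the scatter), even though one carries chlorine and the two differ in how their substituents are arranged on the ring. Among these three compounds, then, both acceptor-free groups stand on the same side of 2-methoxyphenyl and none goes against that, but no measurement at hand explains these steps.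

The chlorine and the methyl enter together in compound 3, so the compounds shown leave open what each contributes, a question that 2-chlorophenyl or 4-methylphenyl at the same place would address. Also open, on these data alone, is whether a more different substituent on this ring, such as a nitrile or an amine, would stay with compound 1 and compound 3 or fall nearer compound 2.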